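The compounds below may be only part of what the source reports. "The series", "measured", "known", "first", "only" and "open" are said of these compounds alone.

Measured in a functional assay on Vero cells (Chlorocebus sabaeus) for cytotoxicity; on this read-out higher numbers stand for weaker inhibition and lower numbers for stronger inhibition:

- Compound 1 `Nc1nc(=O)n([C@H]2C=C(F)[C@@H](CO)O2)cc1F`: > 100000 nM
- Compound 2 `Nc1ccn([C@@H]2C=C(F)[C@H](CO)O2)c(=O)n1`: > 100000 nM

Neither entry is a number. Compound 1 reads > 100000 nM, which is a limit of the assay. Compound 2 reads > 100000 nM, which is likewise a limit, so its position is bounded on one side only. Together the two compounds sit at the limit of > 100000 nM in this assay, at which 2 of the 2 values shown sit, and no step between measured compounds can be sized from them.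

The next compound, compound 3 `Nc1nc(=O)n([C@@H]2C=C(F)[C@H](CO)O2)cc1F`, departs from compound 2 by a single substitution: fluoro in place of hydrogen on an aromatic carbon. In words, it carries fluoro in place of hydrogen on an aromatic carbon, ortho to an amino group.

With both measured compounds at the same limit, no change beyond the usual scatter is expected in this assay. The expected size of this change is a number no higher from compound 2 to compound 3 (the limit leaves the size open). The estimated value for compound 3 is 100000 nM. The expected range for compound 3 runs from 30000 nM to 300000 nM, and the assay will most likely report only a limit again.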

Compound 3, half-maximal inhibitory concentration: > 100000 nM
Compound 3 was reported as a limit (the forecaster's own chance of this, stated with the estimate: 80%); the middle value lies on the limit itself.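

In this assay compound 3 reads > 100000 nM, which is a limit. Its steps from compound 2 and from compound 1 cannot be read: the limit of > 100000 nM in this assay, at which 3 of the 3 values shown sit. The compounds shown leave open whether fluoro in place of hydrogen, or the inverted configuration that separates compound 1 from compound 3, changes this read-out at all.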